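Replacing the dinitrophenyl group of compound 1

The compounds below may be only part of what the source reports. "The series", "measured", "known", "first", "only" and "open" are said of these compounds alone.

Compound 1 `Cc1cc(C)cc(NC(=O)NCCNS(=O)(=O)c2ccc(-c3ccccc3Oc3ccc([N+](=O)[O-])c([N+](=O)[O-])c3)s2)c1`: 12000 nM
Compound 2 `O=C(NCCNS(=O)(=O)c1ccc(-c2ccccc2Oc2ccc([N+](=O)[O-])c([N+](=O)[O-])c2)s1)Nc1ccc([N+](=O)[O-])cc1`: > 20000 nM (a limit)
Compound 3 `COc1cccc(NC(=O)NCCNS(=O)(=O)c2ccc(-c3ccccc3Oc3ccc([N+](=O)[O-])c([N+](=O)[O-])c3)s2)c1`: > 20000 nM (a limit)

For the measured compounds named here, in a functional assay on HeLa cells (Homo sapiens) for inhibition, read by CCK-8 assay, with a stated time of 48 h (on this read-out lower numbers stand for stronger inhibition and higher numbers for weaker inhibition), compound 1 gives 12000 nM, the only true number in this set. Compound 2 and compound 3 give only (the limit of > 20000 nM in this assay, at which 2 of the 3 values shown sit).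

Compound 4 `Cc1cc(C)cc(NC(=O)NCCNS(=O)(=O)c2ccc(-c3ccccc3OCc3cccc(O)c3)s2)c1` keeps the rest of compound 1 but changes one group: 3-hydroxybenzyl in place of 3,4-dinitrophenyl on an oxygen on an aromatic ring. Here, 3-hydroxybenzyl stands in place of 3,4-dinitrophenyl on an oxygen on an aromatic ring.

The measured steps, an at least 1.6-fold higher number from compound 1 to compound 2 (0.22 log units; that floor lies within the scatter) and an at least 1.6-fold higher number from compound 1 to compound 3 (0.22 log units; that floor lies within the scatter), concern a different group, on an amide-type nitrogen, so neither gives a size for this swap. With nothing measured at this place, no shift beyond the scatter is expected in this assay.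

The expected step is no change at the digits printed from compound 1 to compound 4 (within the scatter).

For compound 4 the estimate is 12000 nM, with an expected range from 4000 nM to 30000 nM.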

Compound 4, half-maximal inhibitory concentration: > 20000 nM
Compound 4: only a limit was reported (the forecaster's own chance of this, stated with the estimate: 40%); middle value at least 1.6-fold (0.22 log units) from the limit.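

This is the first change shown at the oxygen on an aromatic ring: 3-hydroxybenzyl in place of 3,4-dinitrophenyl gives an at least 1.6-fold higher number from compound 1 to compound 4 (0.22 log units; that floor lies within the scatter) in this assay. Compound 4 has only a limit, so this step neither shows a real difference from compound 1 nor rules one out. Most of the set now sits at one ceiling: the limit of > 20000 nM in this assay, at which 3 of the 4 values shown sit.

From the compounds shown here alone, the true value of compound 4 remains open. So does whether a plain benzyl group, or an aminobenzyl group, at this oxygen would give a true number.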